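The source may report more compounds than this note shows. Statements on the series, on what has been measured and on what is new or still open speak of the compounds shown alone.

Compound 3 `COc1cc(C2CC(c3ccccc3)=NN2C(C)=O)ccc1OCc1cn(Cc2ccc([N+](=O)[O-])cc2)nn1` gives the lowest of the three values recorded in a functional assay on THP-1 cells (Homo sapiens) for inhibition, read by sulforhodamine B assay, tested at 100 uM (a higher number here means more inhibition of growth at the concentration tested, a lower number less inhibition of growth), at 10%. Compound 2 `COc1cc(C2CC(c3ccc(Br)cc3)=NN2C(C)=O)ccc1OCc1cn(Cc2ccc([N+](=O)[O-])cc2)nn1` gives 23% in this assay, and compound 1 `COc1ccc(C2CC(c3ccc(OCc4cn(Cc5ccc([N+](=O)[O-])cc5)nn4)cc3)=NN2C(C)=O)cc1` gives 26%. Compound 4 `COc1cc(C2CC(c3ccc(Cl)cc3)=NN2C(C)=O)ccc1OCc1cn(Cc2ccc([N+](=O)[O-])cc2)nn1` differs from compound 3 in one place: chloro in place of hydrogen on an aromatic carbon. Going by the values given here, the single measured step that bears on this change is the one in which hydrogen replaced bromo on an aromatic carbon of the same ring, a number 13 percentage points lower from compound 2 to compound 3 (beyond the scatter), a modest drop. Putting a halogen back at that carbon, now chloro, is expected to recover a gain of roughly that size, though all values here are small. Compound 4 is therefore estimated at 21%, with a range from 9% to 33%, corresponding to an expected step of a number 11 percentage points higher from compound 3 to compound 4 (beyond the scatter).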

Compound 4, percent growth inhibition at one concentration: 37%
Estimate against measurement, compound 4: 16 percentage points below; the whole stated range lies below it.
By their numbers in this assay, from the lowest: compound 3; then compounds 2 and 1 (each within the scatter of the next); then compound 4.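

Chloro in place of hydrogen at this aromatic carbon, para to a large group, gives a number 27 percentage points higher from compound 3 to compound 4 (beyond the scatter) in this assay and so places compound 4 above all the others shown. Chloro in place of bromo gives a number 14 percentage points higher from compound 2 to compound 4 (beyond the scatter) in the same read-out, which shows that the result at this carbon depends on which halogen sits there, not only on a halogen being present. No measurement shown here accounts for the difference between chloro and bromo. From the compounds shown here alone, whether fluoro, methyl or an amine at this carbon would match chloro stays open.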